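Adding 4-bromophenyl to the glycine ester chain

The source may hold more compounds than are shown below. What is called first, only, known or untested is meant among the compounds shown, and "the series" means these compounds.

Values in a functional assay on K562 cells (Homo sapiens) for cytotoxicity, read by trypan blue exclusion, with a stated time of 96 h; a lower number here means a stronger inhibitor, a higher number a weaker inhibitor:
- compound 1 `COc1ccc(CS(=O)(=O)/C=C/c2c(OC)cc(O)cc2OC)cc1[N+](=O)[O-]`: 5000 nM
- compound 2 `COc1cc(OC)c(/C=C/SCc2ccc(OC)c(N)c2)c(OC)c1`: 30 nM
- compound 3 `COC(=O)CNc1cc(CS(=O)(=O)/C=C/c2c(OC)cc(OC)cc2OC)ccc1OC`: 100 nM

Compound 3 stands second highest of the three, higher than compound 2 and lower than compound 1. The change to compound 4 `COC(=O)C(Nc1cc(CS(=O)(=O)/C=C/c2c(OC)cc(OC)cc2OC)ccc1OC)c1ccc(Br)cc1` is 4-bromophenyl in place of hydrogen on a saturated chain carbon bound to a carbonyl carbon and a nitrogen on an aromatic ring, made on a saturated chain carbon bound to a carbonyl carbon and a nitrogen on an aromatic ring. For the measured compounds named here, no measured pair tests a change at this place, so the expectation is tentative. The estimated step in this assay is a 3.0-fold higher number from compound 3 to compound 4 (0.48 log units; beyond the scatter), towards a higher number and a weaker inhibitor, expected to lie modestly beyond the scatter. For compound 4 the expected value is 300 nM, with an estimated range of 60 nM to 1500 nM.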

Compound 4, half-maximal inhibitory concentration: 200 nM
Estimate against measurement, compound 4: 1.5-fold (0.18 log units) above, within the range that was stated.
By their numbers in this assay, from the lowest: compound 2; then compounds 3 and 4 (each within the scatter of the next); then compound 1.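

In this assay, for the compounds shown here, 4-bromophenyl in place of hydrogen on the saturated chain carbon bound to a carbonyl carbon and a nitrogen on an aromatic ring gives the first reading at this position (a 2.0-fold higher number from compound 3 to compound 4 (0.30 log units; within the scatter)). With this step inside the scatter, compound 3 and compound 4 cannot be told apart, so the 7 heavy atoms entering here leave the read-out unmoved. Nothing measured on hand bears on this outcome. From the compounds shown here alone, whether a carboxylic acid in place of the methoxycarbonyl group reads the same stays open. So does whether an unsubstituted phenyl or a longer chain at this carbon matches 4-bromophenyl.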